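Chloro for hydrogen on the benzyl ring of compound 2

The source may report more compounds than this note shows. Statements on the series, on what has been measured and on what is new or still open speak of the compounds shown alone.

Measured compounds:
Compound 1, `CC(C)(C)c1ccc(CNCCNS(=O)(=O)c2cc(C(F)(F)F)cc(C(F)(F)F)c2)cc1`: 14000 nM
Compound 2, `O=S(=O)(NCCCNCc1cccc(Cl)c1)c1cc(C(F)(F)F)cc(C(F)(F)F)c1`: 2700 nM
Compound 3, `O=S(=O)(NCCNCc1cccc2ccccc12)c1cc(C(F)(F)F)cc(C(F)(F)F)c1`: 18000 nM

All three share the same sulfonamide-bearing core and differ in the aryl group on the saturated chain carbon bound to the amine nitrogen, and in the length of the chain between the two nitrogens. In a functional assay on HPAC cells (Homo sapiens) for inhibition, read by MTT assay, with a stated time of 72 h (a lower number here means a stronger inhibitor of growth, a higher number a weaker inhibitor of growth), compound 2 gives the lowest of the three numbers; compound 1 sits above it by a gap beyond the scatter, and compound 3 further above it, also beyond the scatter. Going by the values given here, the only step between two compounds differing in a single place, a 1.3-fold higher number from compound 1 to compound 3 (0.11 log units; within the scatter), swaps one aryl group for another and stays within the scatter.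

Compound 4, `O=S(=O)(NCCCNCc1ccc(Cl)c(Cl)c1)c1cc(C(F)(F)F)cc(C(F)(F)F)c1`, differs from compound 2 by chloro in place of hydrogen on an aromatic carbon. Among the compounds with values here, no measured step adds a chloro group to an aromatic carbon, so nothing bears directly on this change; the one step that is measured concerns the whole aryl group and is small. Compound 4 is therefore expected to stay close to compound 2 in this assay, with no step beyond the scatter: a 1.1-fold lower number from compound 2 to compound 4 (0.03 log units; within the scatter). The estimate for compound 4 in this assay is 2500 nM, with a range from 1000 nM to 6500 nM.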

Compound 4, concentration for 50% growth inhibition: 2500 nM
Estimate against measurement, compound 4: no gap at the digits printed, and the stated range covers the measured number.
By their numbers in this assay, from the lowest: compounds 4 and 2 (each within the scatter of the next); then compounds 1 and 3 (each within the scatter of the next).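

In this assay, going from 3-chlorobenzyl to 3,4-dichlorobenzyl gives a 1.1-fold lower number from compound 2 to compound 4 (0.03 log units; within the scatter), so the added chloro group, ortho to a chloro group and para to a large group, leaves the growth-inhibition number unchanged within the scatter. This is the series' first step confined to a single ring position with the chain held constant, whereas the earlier step exchanged one whole aryl group for another; this carbon of the benzyl ring can therefore carry a second chloro group with no change beyond the scatter in this assay. Nothing measured here explains why the number holds at this position.

Still open, from the compounds shown here alone, is whether this position accepts groups other than chloro, such as a methoxy group, an amine or a carboxylic acid, and whether the same holds for a benzyl ring without the first chloro group. The compounds shown also leave the effect of chain length unseparated from that of the aryl group, and a longer chain remains an open question for the 3,4-dichlorobenzyl compound.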